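The source may report more compounds than this note shows. Statements on the series, on what has been measured and on what is new or still open speak of the compounds shown alone.

In an ADME assay on microsomes from liver (Mus musculus, strain CD1) for metabolic stability, read by HPLC, using NADPH, with a stated time of 30 min, tested at 0.5 uM (a lower number here means slower removal, a higher number faster removal of the compound), compound 2 `CC(C)[C@H]1CC[C@H](n2c(=O)[nH]c3ncc(N)cc3c2=O)CC1` stands highest of the two measured compounds with 1.9 mL.min-1.g-1 against 0.5 mL.min-1.g-1 for compound 1 `CC[C@H]1CC[C@H](n2c(=O)[nH]c3ncc(NC(C)=O)cc3c2=O)CC1` and that gap lies beyond the scatter. Compound 3 `CC[C@H]1CC[C@H](n2c(=O)[nH]c3ncc(N)cc3c2=O)CC1` differs from compound 2 by hydrogen in place of methyl on a saturated chain carbon bound to a saturated chain carbon and a saturated ring carbon in a change that reads isopropyl to ethyl, with hydrogen in place of methyl on a saturated chain carbon bound to a saturated chain carbon and a saturated ring carbon. Among the measured compounds shown here, no measured pair shows this change alone, so only a small fall within the scatter is expected, and the estimated move a 1.6-fold lower number from compound 2 to compound 3 (0.20 log units; within the scatter) is of that size. Compound 3 is estimated at 1.2 mL.min-1.g-1 with an expected range from 0.6 mL.min-1.g-1 to 2.4 mL.min-1.g-1 in this measurement.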

Compound 3, intrinsic clearance in microsomes: 0.9 mL.min-1.g-1
Compound 3: middle estimate off by 1.3-fold (0.12 log units), on the high side; the range from low to high includes it.
By their numbers in this assay, from the lowest: compounds 1 and 3 (each within the scatter of the next); then compound 2.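

In this assay, among the compounds shown here, the change from isopropyl to ethyl gives a 2.1-fold lower number from compound 2 to compound 3 (0.32 log units; beyond the scatter), a modest step beyond the scatter and the first reading of hydrogen in place of methyl on this saturated chain carbon. Hydrogen in place of acetyl on a nitrogen on an aromatic ring gives a 1.8-fold higher number from compound 1 to compound 3 (0.26 log units; within the scatter), which lies within the scatter, so with ethyl in place, this swap shows no clear effect on the number. Left open is how a longer chain or a hydroxyl group on this carbon would read, and whether acetyl in place of hydrogen would show the same with isopropyl present. Nothing shown here gives a reason for either step.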